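A few compounds are considered here, and "the series" means these few. Any claim that something is new, unique, unknown or untested is made for them only; others in the source may bear on it.

Working notes on the series. In a functional assay on cells (Melanoma cell, Homo sapiens) for cytotoxicity, with a stated time of 48 h (on this read-out higher numbers stand for weaker inhibition of growth and lower numbers for stronger inhibition of growth), compound 1 `COc1ccc(CN2C(=O)/C(=C\c3cc(OC)c(OC)c(OC)c3)c3ccccc32)cc1` gives 4500 nM, the lower of the two numbers recorded so far. Compound 2 `COc1cc(/C=C2\C(=O)N(C)c3ccc(Cl)cc32)cc(OC)c1OC`, which carries a different core substitution pattern, gives 21400 nM in this assay, a higher number than compound 1 and beyond the scatter. Compound 3 `COc1cc(/C=C2\C(=O)N(Cc3ccc(Cl)cc3)c3ccccc32)cc(OC)c1OC` has not yet been measured. It differs from compound 1 by chloro in place of methoxy on an aromatic carbon. For the measured compounds named here, with no measured pair showing this change, a step within the scatter is expected, as a 1.2-fold higher number from compound 1 to compound 3 (0.09 log units; within the scatter). Compound 3 is therefore estimated at 5500 nM, likely between 2000 nM and 15000 nM.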

Compound 3, concentration for total growth inhibition: 8900 nM
For compound 3 the middle estimate is 1.6-fold (0.21 log units) below the measured one; the measured number falls inside the stated range.
By their numbers in this assay, from the lowest: compounds 1 and 3 (each within the scatter of the next); then compound 2.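

Replacing 4-methoxybenzyl with 4-chlorobenzyl gives a 2.0-fold higher number from compound 1 to compound 3 (0.30 log units; within the scatter) in this assay, so this read-out does not separate these two groups at this position. For the compounds shown here, compound 1 and compound 3 therefore give the first single-place comparison, and it shows a swap of methoxy for chloro that stays within the scatter. Nothing at hand offers an explanation for this result. Still open, on these data alone, is whether an amine, a carboxylic acid or a longer chain at this position would give a step beyond the scatter. Also open, as far as these compounds go, is whether the same swap would behave alike at another place on the ring.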